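The source may report more compounds than this note shows. Statements on the series, on what has been measured and on what is new or still open speak of the compounds shown alone.

The series shares one core, seen in compound 1 `CC1(C)[C@H]2CC[C@]1(C)N(Cc1cn(-c3ccccc3Br)nn1)C(=O)C2`. In a functional assay on A549 cells (Homo sapiens) for inhibition, read by MTT assay, with a stated time of 24 h (on this read-out lower numbers stand for stronger inhibition and higher numbers for weaker inhibition), compound 1 gives 130 nM, the second highest of the three numbers at hand. Compound 3 `CC1(C)[C@H]2CC[C@]1(C)N(Cc1cn(-c3ccccc3Cl)nn1)C(=O)C2` gives 70 nM and compound 2 `CC1(C)[C@H]2CC[C@]1(C)N(Cc1cn(-c3cccc(C#N)c3)nn1)C(=O)C2` gives 440 nM. Compound 4 `CC1(C)[C@H]2CC[C@]1(C)N(Cc1cn(-c3ccccc3O)nn1)C(=O)C2` differs from compound 1 thus: hydroxy in place of bromo on an aromatic carbon. Within the data shown here, no measured step exchanges a halogen for a hydroxy group on this ring. The closest guidance is a 1.9-fold lower number from compound 1 to compound 3 (0.27 log units; within the scatter), one halogen for another, and a 3.4-fold higher number from compound 1 to compound 2 (0.53 log units; beyond the scatter), a different substituent at a different place on the ring. A small to modest weakening is therefore expected for compound 4, a 1.9-fold higher number from compound 1 to compound 4 (0.28 log units; within the scatter). For compound 4 the expected value is 250 nM, in the range 80 nM to 800 nM.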

Compound 4, half-maximal inhibitory concentration: 230 nM
Compound 4: the middle estimate sits 1.1-fold (0.04 log units) above what was measured; the measured number falls inside the stated range.
By their numbers in this assay, from the lowest: compounds 3, 1, 4 and 2 (each within the scatter of the next, the first and the last beyond it).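

On the aromatic carbon ortho to a large group, hydroxy, which adds a hydrogen-bond donor and acceptor, stays within the scatter of bromo (a 1.8-fold higher number from compound 1 to compound 4 (0.25 log units; within the scatter)) but is separated from chloro (a 3.3-fold higher number from compound 3 to compound 4 (0.52 log units; beyond the scatter)) in this assay. The 2-hydroxyphenyl compound also stays within the scatter of the 3-cyanophenyl compound (a 1.9-fold lower number from compound 2 to compound 4 (0.28 log units; within the scatter)). Nothing at hand accounts for these steps.

Open, going by these compounds, is how an amine, a carboxylic acid or a methoxy group would read at this position. Also open, on these data alone, is how hydroxy would read at the nitrile's place in compound 2.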